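Trifluoromethyl for ethyl on the sulfonamide sulfur

The source may hold more compounds than are shown below. What is called first, only, known or untested is meant among the compounds shown, and "the series" means these compounds.

Compound 1 `CCS(=O)(=O)Nc1ccc(NC(=O)c2cc(C(F)(F)F)cc(C(F)(F)F)c2)cc1C` is measured in an ADME assay on HEK293 cells (Homo sapiens) for cytotoxicity, read by MTT assay, with a stated time of 48 h (a lower number here means a stronger inhibitor, a higher number a weaker inhibitor), at 126000 nM. Compound 2 `Cc1cc(NC(=O)c2cc(C(F)(F)F)cc(C(F)(F)F)c2)ccc1NS(=O)(=O)C(F)(F)F` differs from it by trifluoromethyl in place of ethyl on a sulfonyl sulfur; in this assay compound 2 gives 182000 nM. The measured step of a 1.4-fold higher number from compound 1 to compound 2 (0.16 log units; within the scatter) is small. Compound 3 `CCS(=O)(=O)Nc1ccc(NC(=O)c2cccc(C(F)(F)F)c2)cc1OC` shares only part of its structure with compound 1; the difference between the two cores is not broken down here. In this assay compound 3 reaches only a limit, > 250000 nM. Compound 4 `COc1cc(NC(=O)c2cccc(C(F)(F)F)c2)ccc1NS(=O)(=O)C(F)(F)F` is not yet measured; it differs from compound 3 by trifluoromethyl in place of ethyl on a sulfonyl sulfur, which is the same change as from compound 1 to compound 2, at the same place. The step that the limit leaves unreadable from compound 3 to compound 4 is expected to be small because a 1.4-fold higher number from compound 1 to compound 2 (0.16 log units; within the scatter) lay within the scatter and compound 3 already stands at the limit of > 250000 nM in this assay, at which 1 of the 3 values shown sits. Compound 4 is therefore estimated at 300000 nM, most likely reported again only as a limit.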

Compound 4, half-maximal inhibitory concentration: > 250000 nM
Compound 4: a limit, no number; the forecaster's own chance of this, stated with the estimate: 85%; the middle value does not contradict the limit.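

Compound 3 and compound 4 both stand only at a limit in this assay, and no new step can be read between them. The compounds shown leave open whether trifluoromethyl in place of ethyl on a sulfonyl sulfur has any measurable size on this pair.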